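A few compounds are considered here, and "the series" means these few. Any claim that something is new, unique, unknown or untested is made for them only; others in the source may bear on it.

Measured so far:
- compound 1 `Cc1ccccc1S(=O)(=O)n1c(=O)[nH]c2ccc(Cl)cc21`: > 387000 nM, a limit of the assay
- compound 2 `Cc1ccc(S(=O)(=O)n2c(=O)[nH]c3ccc(Cl)cc32)cc1`: 134000 nM
- compound 3 `Cc1ccc(C)c(S(=O)(=O)n2c(=O)[nH]c3ccc(Cl)cc32)c1`: > 371000 nM, a limit of the assay

All three share one core and were tested in an ADME assay on MT4 cells (Homo sapiens) for cytotoxicity; a higher number here means that more compound is tolerated, a lower number that less compound is tolerated. Compound 1 and compound 2 are built from the same atoms joined differently: 4-methylphenyl in place of 2-methylphenyl on a sulfonyl sulfur. This gives an at least 2.8-fold lower number from compound 1 to compound 2 (0.46 log units; beyond the scatter). Compound 3 differs from compound 1 by a single added group: methyl in place of hydrogen on an aromatic carbon. The step here is a step that the two limits leave unreadable from compound 1 to compound 3, because the limit of > 387000 nM in this assay, at which 1 of the 3 values shown sits, and the limit of > 371000 nM in this assay, at which 1 of the 3 values shown sits, both hide the true values.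

Compound 4 `Cc1ccc(S(=O)(=O)n2c(=O)[nH]c3ccc(Cl)cc32)cc1C` has not yet been measured. It carries the same kind of change relative to compound 2: methyl in place of hydrogen on an aromatic carbon. The surroundings differ, though: in compound 3 the new methyl sits para to a methyl group and meta to a large group, while in compound 4 it sits ortho to a methyl group and meta to a large group.

From compound 2, the estimated step for compound 4 in this assay is a 1.6-fold higher number from compound 2 to compound 4 (0.22 log units; within the scatter), resting on compound 2 giving 134000 nM and on the unreadable but non-lowering step that the two limits leave unreadable from compound 1 to compound 3. Compound 4 is therefore expected to give about 220000 nM, with a likely range from 100000 nM to 450000 nM.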

Compound 4, half-maximal cytotoxic concentration: > 371000 nM
Compound 4 gave a limit, no number; the forecaster's own chance of this, stated with the estimate: 40%; at least 1.6-fold (0.22 log units) between middle value and limit.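

In this assay, methyl in place of hydrogen on an aromatic carbon of the core of compound 2 gives an at least 2.7-fold higher number from compound 2 to compound 4 (0.44 log units; beyond the scatter), and the upper end of this step is a limit of the assay, not a number. The step from compound 1 to compound 3, the same kind of change on a differently substituted core, cannot be read, because compound 1 sits at a limit of its own and compound 3 at this one: the limit of > 371000 nM in this assay, at which 2 of the 4 values shown sit.

So one readable step stands alone, and it does not show that the change has the same size, or even the same direction, on both cores. The compounds shown leave open how far the true values of compound 1, compound 3 and compound 4 lie from their limits. They also leave open whether an amine or a carboxylic acid in the place of the added methyl would give a number as high in this assay.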